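A Chloro-to-Trifluoromethyl Swap Without a Close Precedent

This account rests on a few compounds, and the source may have more. Where it says the series, first, only, none or still open, it means among the compounds named here.

Three measured compounds share one core and differ only in the group attached to an amine nitrogen in a ring. Compound 1 `Cc1ccccc1CN1CCc2c(sc(NC(=O)c3ccccc3Cl)c2C(N)=O)C1` carries a methyl-substituted benzyl group there. In a functional assay on HL-60 cells (Homo sapiens) for antiproliferative activity, with a stated time of 24 h (on this read-out lower numbers stand for stronger inhibition and higher numbers for weaker inhibition), compound 1 reaches only > 50000 nM, which is a limit of the assay rather than a number. That value is the limit of > 50000 nM in this assay, at which 1 of the 3 values shown sits. Compound 2 `N#Cc1ccccc1CN1CCc2c(sc(NC(=O)c3ccccc3Cl)c2C(N)=O)C1` has a cyano in place of the methyl, and in this assay compound 2 gives 10400 nM, so there is an at least 4.8-fold lower number from compound 1 to compound 2 (0.68 log units; beyond the scatter). Compound 3 `COc1ccccc1NC(=S)N1CCc2c(sc(NC(=O)c3ccccc3Cl)c2C(N)=O)C1` instead bears a group of 11 heavy atoms on that nitrogen; in this assay compound 3 gives 40900 nM. Against the others this means a 3.9-fold higher number from compound 2 to compound 3 (0.59 log units; beyond the scatter) and an at least 1.2-fold lower number from compound 1 to compound 3 (0.08 log units; that floor lies within the scatter). Compound 3 therefore stands with the highest of the two actual numbers, its nearest neighbour being compound 2.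

Compound 4 `COc1ccccc1NC(=S)N1CCc2c(sc(NC(=O)c3ccccc3C(F)(F)F)c2C(N)=O)C1` differs from compound 3 in one place: trifluoromethyl in place of chloro on an aromatic carbon. Going by the values given here, none of the three measured steps touches this part of the molecule; each of them alters the group on the amine nitrogen in a ring, so no measured step bears directly on the change. The expectation is therefore no step beyond the scatter. Compound 4 is estimated at 40000 nM, with a range from 12000 nM to 130000 nM. The expected step is a 1.0-fold lower number from compound 3 to compound 4 (0.01 log units; within the scatter).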

Compound 4, half-maximal inhibitory concentration: > 50000 nM
Compound 4: a limit, no number; the forecaster's own chance of this, stated with the estimate: 40%; middle value at least 1.2-fold (0.09 log units) from the limit.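

Going by these compounds alone, this is the first look at the other end of the molecule, the ring of the benzoyl-type amide, since every earlier step changed only the group on the ring amine nitrogen. In this assay compound 4 gives > 50000 nM, which is a limit of the assay and not a number. The swap of chloro for trifluoromethyl, on an aromatic carbon ortho to a large group, therefore reads only as an at least 1.2-fold higher number from compound 3 to compound 4 (0.08 log units; that floor lies within the scatter), so it gives no sign of a lower number at this position, though the true size of the change stays unknown, and the result adds one more compound to the top of the measurable range: the limit of > 50000 nM in this assay, at which 2 of the 4 values shown sit.

Going by these compounds, whether a different group at this place, such as a lone fluorine or an amine, would bring the number down remains open. Also open, on these data alone, is how the same swap would read with the cyano-bearing benzyl group of compound 2, which gives 10400 nM and so leaves more room for a change in either direction to appear as a number.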